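Swapping Phenyl for Methylpyridinyl in a Dehydrogenase Inhibitor Series

The compounds below may be only part of what the source reports. "The series", "measured", "known", "first", "only" and "open" are said of these compounds alone.

Of the compounds shown here, three sharing one core have been measured in an assay on HeLa cells for inhibition of 17-beta-hydroxysteroid dehydrogenase type 3 (Homo sapiens); a lower number here means a stronger inhibitor, a higher number a weaker inhibitor. Compound 1 `O=c1cc(CCc2ccccc2)c2ccc(O)cc2o1` gives 20 nM, the lowest of the three numbers and thus the strongest inhibitor among them. Compound 2 `O=c1cc(CSc2ncccn2)c2ccc(O)cc2o1`, carrying a pyrimidin-2-yl on a sulfur, gives 1000 nM, while compound 3 `Cn1ccnc1SCc1cc(=O)oc2cc(O)ccc12`, with a 1-methyl-1H-imidazol-2-yl on that sulfur, gives 91 nM. For the measured compounds named here, the one directly comparable step, an 11-fold lower number from compound 2 to compound 3 (1.04 log units; beyond the scatter), shows that exchanging one hetero-ring for another at the same place can move this assay by a large amount.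

Compound 4 `Cc1cccc(CCc2cc(=O)oc3cc(O)ccc23)n1` differs from compound 1 in one place: 6-methylpyridin-2-yl in place of phenyl on a saturated chain carbon, two bonds along the chain from an aromatic carbon. Going by the values given here, no measured pair mirrors this change. The step from compound 2 to compound 3 concerns a sulfur-linked ring, and compounds 1 and 2 differ in both ring and linker, so their values only show that the chain-linked phenyl compound is the stronger one. A modest loss is therefore expected: compound 4 is estimated at 60 nM, within 15 nM to 250 nM, an expected step of a 3.0-fold higher number from compound 1 to compound 4 (0.48 log units; beyond the scatter).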

Compound 4, half-maximal inhibitory concentration: 8 nM
Compound 4: the middle estimate sits 7.5-fold (0.88 log units) above what was measured; measured number below the stated range.
By their numbers in this assay, from the lowest: compound 4; then compound 1; then compound 3; then compound 2.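

The phenyl of compound 1 can be replaced at this place on the chain without loss. In this assay, 6-methylpyridin-2-yl in its place gives a 2.5-fold lower number from compound 1 to compound 4 (0.40 log units; beyond the scatter), so a ring with a hetero atom and one more heavy atom is accepted there, and the number even improves by a modest amount. The earlier compounds showed a ring exchange only on a sulfur, and nothing measured here explains this new gain on the chain.

The change brings in a ring nitrogen and a methyl together, and the compounds shown do not separate the two: that would take a plain pyridin-2-yl or a 3-methylphenyl on the same chain. Also open, on these data alone, is whether the gain would survive a longer chain between the ring and the shared core.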